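Swapping 2,5-dimethylphenyl for 4-chlorophenyl in a growth assay

A few compounds are considered here, and "the series" means these few. Any claim that something is new, unique, unknown or untested is made for them only; others in the source may bear on it.

Of the compounds shown here, three sharing one core have been measured in a functional assay on DU-145 cells (Homo sapiens) for inhibition, read by trypan blue exclusion, with a stated time of 96 h; a higher number here means a weaker inhibitor of growth, a lower number a stronger inhibitor of growth. Compound 1 (`CSc1ccc(/C=C(\C(=O)c2ccc(Cl)cc2)S(=O)(=O)Cc2ccc(C)cc2)cc1`), which carries 4-(methylsulfanyl)phenyl, gives 10000 nM. Compound 2 (`Cc1ccc(CS(=O)(=O)/C(=C/c2cccc(Cl)c2Cl)C(=O)c2ccc(Cl)cc2)cc1`), with 2,3-dichlorophenyl, gives 1000 nM. Compound 3 (`Cc1ccc(CS(=O)(=O)/C(=C/c2cc(C)ccc2C)C(=O)c2ccc(Cl)cc2)cc1`), with 2,5-dimethylphenyl, gives 1000 nM, level with compound 2, and together they hold the lowest of the three numbers.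

Compound 4 (`Cc1ccc(CS(=O)(=O)/C(=C/c2ccc(Cl)cc2)C(=O)c2ccc(Cl)cc2)cc1`) has 4-chlorophenyl in place of 2,5-dimethylphenyl on a double-bonded chain carbon bound to a double-bonded chain carbon.

All three measured steps fall at this same place. Two of them were modest and beyond the scatter, a 10-fold lower number from compound 1 to compound 2 (1.00 log units; beyond the scatter) and a 10-fold lower number from compound 1 to compound 3 (1.00 log units; beyond the scatter), whereas no change at the digits printed from compound 2 to compound 3 (within the scatter) stayed within it. Changes here can therefore shift the number, although the two groups in compound 2 and compound 3 gave the same value. Going by the values given here, the entering 4-chlorophenyl is, like the 4-(methylsulfanyl)phenyl of compound 1 at 10000 nM, a phenyl substituted at its 4 position, so some rise is plausible, though no measured compound tests this group directly. The expected change is small, a 2.0-fold higher number from compound 3 to compound 4 (0.30 log units; within the scatter), and may not clear the scatter. For compound 4 the estimated value is 2000 nM, with an expected range from 500 nM to 8000 nM.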

Compound 4, concentration for 50% growth inhibition: 25000 nM
Beside the measured number, compound 4's estimate is 13-fold (1.10 log units) below it; measured number above the stated range.
By their numbers in this assay, from the lowest: compounds 2 and 3 (each within the scatter of the next); then compound 1; then compound 4.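

In this assay, going by these compounds alone, this place on a double-bonded chain carbon bound to a double-bonded chain carbon proves more sensitive than the earlier compounds showed, with a 25-fold higher number from compound 3 to compound 4 (1.40 log units; beyond the scatter) and a 25-fold higher number from compound 2 to compound 4 (1.40 log units; beyond the scatter) both large, while the earlier steps here were modest or within the scatter. The tie between 2,5-dimethylphenyl and 2,3-dichlorophenyl now stands apart from both other groups, since the compounds carrying 4-(methylsulfanyl)phenyl and 4-chlorophenyl hold the two highest numbers, and a 2.5-fold higher number from compound 1 to compound 4 (0.40 log units; beyond the scatter) shows that the change from methylsulfanyl to chloro on an aromatic carbon also moves the number beyond the scatter. No measurement given here accounts for the size or direction of these steps.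

The four compounds leave open whether the separation follows the placing of groups on the phenyl ring or the identity of the groups themselves, as each compound differs in both. Going by these compounds, it also remains open where an unsubstituted phenyl, or a phenyl bearing an amine or a carboxylic acid, would fall at this place on the shared core.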